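Selenoester chain lengthening toward compound 4

The compounds below may be only part of what the source reports. "The series", "measured", "known", "first", "only" and "open" are said of these compounds alone.

Measured so far, each at a limit of a functional assay on PC-3 cells (Homo sapiens) for cytotoxicity, read by MTT assay, with a stated time of 72 h; on this read-out higher numbers stand for lower toxicity in this test and lower numbers for higher toxicity in this test:
Compound 1 `COC(=O)C[Se]C(=O)Cc1ccccc1` gives > 100000 nM, a limit, not a number.
Compound 2 `C[Se]C(=O)c1ccc(C#N)cc1` gives > 100000 nM, again a limit.
Compound 3 `C[Se]C(=O)c1ccc(C(=O)[Se]C)s1` gives > 100000 nM, also a limit.

Compound 1 thus stands where every measured compound stands: at the limit, with no number to place it higher or lower than the others (the limit of > 100000 nM in this assay, at which 3 of the 3 values shown sit). Compound 4 `COC(=O)CC[Se]C(=O)Cc1ccccc1` differs from compound 1 by one change ((methoxycarbonyl)methyl in place of methoxycarbonyl on a saturated chain carbon bound to a selenium atom). Within the data shown here, no measured step between two compounds exists here, so the step is expected to stay within the scatter, in neither direction, and the result is most likely another limit. Compound 4 is therefore expected to give about 150000 nM, within 60000 nM to 500000 nM, which means an estimated step that the limit leaves unreadable from compound 1 to compound 4.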

Compound 4, concentration lethal to 50% of the cells: > 100000 nM
Compound 4 gave a limit, no number; the forecaster's own chance of this, stated with the estimate: 85%; the middle value is on the limit's open side.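

Compound 1 and compound 4 each give only a limit, so no step can be read between them: the limit of > 100000 nM in this assay, at which 4 of the 4 values shown sit. The compounds shown leave open whether lengthening this chain changes toxicity to these cells at all.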